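Trifluoromethoxy in Place of Trifluoromethyl on a Shared Core

The source may hold more compounds than are shown below. What is called first, only, known or untested is meant among the compounds shown, and "the series" means these compounds.

Compound 2 `Oc1ccc(-c2cc(-c3ccc(C(F)(F)F)cc3)cc(-c3cccc(O)c3)n2)cc1` and compound 1 `Oc1ccc(-c2cc(-c3cccc(F)c3)cc(-c3cccc(O)c3)n2)cc1` share the same core and differ only in one aromatic substituent. In a functional assay on HCT-15 cells (Homo sapiens) for inhibition (on this read-out lower numbers stand for stronger inhibition and higher numbers for weaker inhibition), compound 1 gives 3070 nM, and compound 2 gives 6440 nM. The step of a 2.1-fold higher number from compound 1 to compound 2 (0.32 log units; beyond the scatter) shows a modest weakening. Among the measured compounds shown here, compound 2 therefore stands at the higher of the two numbers so far, with compound 1 as its only neighbour.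

Compound 3 `Oc1ccc(-c2cc(-c3ccc(OC(F)(F)F)cc3)cc(-c3cccc(O)c3)n2)cc1` has not yet been measured. It differs from compound 2 by trifluoromethoxy in place of trifluoromethyl on an aromatic carbon. For the measured compounds named here, no measured step swaps these two groups. Going by the values given here, the single step available, a 2.1-fold higher number from compound 1 to compound 2 (0.32 log units; beyond the scatter), concerns a different exchange on that ring and bears on the present change only loosely: it shows that one substituent swap in this position moved the number modestly, without telling the direction for the present swap. Among the compounds with values here, with no direct precedent, the expected step of a 1.0-fold higher number from compound 2 to compound 3 (0.00 log units; within the scatter) is none beyond the scatter, and the range is kept wide to reflect that. Compound 3 is thus estimated at 6500 nM, with a range from 2500 nM to 17000 nM.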

Compound 3, half-maximal inhibitory concentration: 1380 nM
The estimate for compound 3 lay 4.7-fold (0.67 log units) above the measured number, and the stated range ends above it.
By their numbers in this assay, from the lowest: compound 3; then compound 1; then compound 2.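

Putting trifluoromethoxy in place of trifluoromethyl gives, in this assay, a 4.7-fold lower number from compound 2 to compound 3 (0.67 log units; beyond the scatter), so a small edit to this substituent can move the number down, whereas the only earlier step, a 2.1-fold higher number from compound 1 to compound 2 (0.32 log units; beyond the scatter), had shown a move upward. The two groups differ by little on paper, since the entering group has 5 heavy atoms against 4 and 1 hydrogen-bond acceptor against 0, yet that edit takes the number from the highest of the three compounds to the lowest, below even compound 1 at 3070 nM. Nothing measured on these compounds explains why the oxygen-linked group gives the lower number, so the shift stands here as an observation only.

On these data alone, what remains open is whether the oxygen itself matters, which a methoxy group, keeping the oxygen but carrying no fluorine, would help to answer, and whether an amine or a carboxylic acid on the same aromatic carbon would follow the same trend. As far as these compounds go, it is also open whether the lower number with trifluoromethoxy would hold on a core with other groups in place of the two hydroxyl-bearing rings.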